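The compounds below may be only part of what the source reports. "The series", "measured", "known", "first", "only" and "open" are said of these compounds alone.

Two compounds share one core and differ only in where the hydroxyl sits on the phenyl group. Compound 1 is `Oc1ccc(-c2cc(-c3ccccn3)nc(-c3ccccc3Cl)c2)cc1` and compound 2 is `Oc1cccc(-c2cc(-c3ccccn3)nc(-c3ccccc3Cl)c2)c1`. In an assay on isolated protein for inhibition of DNA topoisomerase 1 (Homo sapiens), with a stated time of 30 min, tested at 100 uM (on this read-out lower numbers stand for a weaker effect and higher numbers for a stronger effect at the one concentration tested), compound 1 gives 5.2%, and in this assay compound 2 gives 0%. Compound 1 therefore holds the higher of the two numbers, but the step of a number 5.2 percentage points lower from compound 1 to compound 2 (within the scatter) is within the scatter, so the two compounds cannot be told apart on this read-out. Both numbers are small, so neither compound produces much effect at the concentration tested.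

Compound 3, `Oc1ccc(-c2cc(-c3cccnc3)nc(-c3ccccc3Cl)c2)cc1`, has not been measured. It keeps the 4-hydroxyphenyl group of compound 1 and changes the other aromatic ring: pyridin-3-yl in place of pyridin-2-yl on an aromatic carbon. Within the data shown here, no measured step concerns this pyridyl ring. Among the measured compounds shown here, the only measured step, from compound 1 to compound 2, was within the scatter and touched a different part of the molecule, so it offers no direction for this change. With both measured numbers low, the expected step of a number 0.2 percentage points lower from compound 1 to compound 3 (within the scatter) is none beyond the scatter, and compound 3 is estimated at 5%, between 0% and 15%.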

Compound 3, a percentage reported as inhibition, at one concentration (the size of the read-out at that concentration, not a potency): 0.9%
Estimate against measurement, compound 3: 4.1 percentage points above, and the stated range covers the measured number.
By their numbers in this assay, from the lowest: compounds 2, 3 and 1 (each within the scatter of the next).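

In this assay, among these compounds, the change at this position gives a number 4.3 percentage points lower from compound 1 to compound 3 (within the scatter), the first measured step on the pyridyl ring rather than on the hydroxyphenyl group. Replacing pyridin-2-yl with pyridin-3-yl keeps the same atoms but joins them differently, and this rearrangement does not separate the two compounds on this read-out. Two single changes in different parts of the molecule have now been measured, each with a step within the scatter, and no available measurement bears on this result.

On these data alone, it remains open whether any other group at this position, such as a plain phenyl ring or a pyridine ring carrying an amine or a carboxylic acid, would give a number clearly beyond the scatter. With all three numbers small and each read at a single concentration, the compounds shown also leave open how these structures would compare at other concentrations, and a further loss of effect from a change at this position would be hard to detect.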